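Anilino swap on the bromophenyl member of the series

This account rests on a few compounds, and the source may have more. Where it says the series, first, only, none or still open, it means among the compounds named here.

Three compounds of the series have numbers in a functional assay on MGC-803 cells (Homo sapiens) for inhibition, read by MTT assay, with a stated time of 72 h; a lower number here means a stronger inhibitor, a higher number a weaker inhibitor. Within the data shown here, compound 1 `COc1cc(-c2nc(SCc3cn(CC(=O)NC(=O)Nc4ccccn4)nn3)nc(Nc3cccc(C(F)(F)F)c3)c2C#N)cc(OC)c1OC` gives 8210 nM, and compound 2 `Cc1ccc(-c2nc(SCc3cn(CC(=O)NC(=O)Nc4ccccn4)nn3)nc(Nc3cccc(C(F)(F)F)c3)c2C#N)cc1` gives 7580 nM; the only single-point step, a 1.1-fold lower number from compound 1 to compound 2 (0.03 log units; within the scatter), lies within the scatter. Compound 3 `Cc1ccc(Nc2nc(SCc3cn(CC(=O)NC(=O)Nc4ccccn4)nn3)nc(-c3ccc(Br)cc3)c2C#N)cc1` gives 13900 nM, the highest of the three numbers, though its gaps to compound 1 and compound 2 are both within the scatter.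

Compound 4 `N#Cc1c(Nc2cccc(C(F)(F)F)c2)nc(SCc2cn(CC(=O)NC(=O)Nc3ccccn3)nn2)nc1-c1ccc(Br)cc1` differs from compound 3 by 3-(trifluoromethyl)phenyl in place of 4-methylphenyl on a nitrogen on an aromatic ring. Among the measured compounds shown here, no measured step covers this exchange directly; compound 1 and compound 2 already carry the 3-(trifluoromethyl)phenyl group on that nitrogen and both return numbers somewhat lower than compound 3, but each of those gaps lies within the scatter and the aryl group on the core also differs. The step of a 1.5-fold lower number from compound 3 to compound 4 (0.17 log units; within the scatter) is therefore expected to be small, toward a lower number if anything, and not beyond the scatter. In this assay compound 4 is estimated at 9500 nM, with a range from 4500 nM to 20000 nM.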

Compound 4, half-maximal inhibitory concentration: 3600 nM
Compound 4: middle estimate off by 2.6-fold (0.42 log units), on the high side; the measured number lies below the stated range.
By their numbers in this assay, from the lowest: compound 4; then compounds 2, 1 and 3 (each within the scatter of the next).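

In this assay, the group on the nitrogen now has a reading of its own with the 4-bromophenyl group held constant: 3-(trifluoromethyl)phenyl in place of 4-methylphenyl gives a step beyond the scatter (a 3.9-fold lower number from compound 3 to compound 4 (0.59 log units; beyond the scatter)). The aryl group on the shared core, which showed nothing in the earlier step (a 1.1-fold lower number from compound 1 to compound 2 (0.03 log units; within the scatter)), also moves the number beyond the scatter when the 4-bromophenyl group is present, both against 4-methylphenyl (a 2.1-fold lower number from compound 2 to compound 4 (0.32 log units; beyond the scatter)) and against 3,4,5-trimethoxyphenyl (a 2.3-fold lower number from compound 1 to compound 4 (0.36 log units; beyond the scatter)). No measured evidence bears on these steps.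

The exchange on the nitrogen changes both the substituent and its place on the ring, so 3-methylphenyl or 4-(trifluoromethyl)phenyl would be needed to separate the two. As far as these compounds go, it also remains open whether the step carries over to compounds with another aryl group on the core.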